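Working notes: from compound 3 to compound 4

The compounds below may be only part of what the source reports. "The series", "measured", "known", "first", "only" and "open" are said of these compounds alone.

Values in a functional assay on MCF7 cells (Homo sapiens) for antiproliferative activity, read by MTT assay, with a stated time of 72 h (a lower number here means a stronger inhibitor, a higher number a weaker inhibitor), so far:
compound 1 `CC1=CC[C@H]2[C@H](CC[C@]2(C)O)C(C)(C)[C@@H]1CC[C@H]1[C@]2(C)CC[C@H](OC(=O)c3ccc(F)cc3)C(C)(C)O[C@H]2CC[C@@]1(C)O` gives 33500 nM
compound 2 `CC1=CC[C@H]2[C@H](CC[C@]2(C)O)C(C)(C)[C@@H]1CC[C@H]1[C@]2(C)CC[C@H](OC(=O)c3ccc(C(F)(F)F)cc3)C(C)(C)O[C@H]2CC[C@@]1(C)O` gives 23400 nM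
compound 3 `CC1=CC[C@H]2[C@H](CC[C@]2(C)O)C(C)(C)[C@@H]1CC[C@H]1[C@]2(C)CC[C@H](OC(=O)c3cccc(C(F)(F)F)c3)C(C)(C)O[C@H]2CC[C@@]1(C)O` gives 37900 nM

Compound 3 cannot be separated from the other two compounds on these numbers. Its two steps, a 1.1-fold higher number from compound 1 to compound 3 (0.05 log units; within the scatter) and a 1.6-fold higher number from compound 2 to compound 3 (0.21 log units; within the scatter), both stay within the scatter.

Compound 4 `CC1=CC[C@H]2[C@H](CC[C@]2(C)O)C(C)(C)[C@@H]1CC[C@H]1[C@]2(C)CC[C@H](OC(=O)c3ccc(C(F)(F)F)cc3F)C(C)(C)O[C@H]2CC[C@@]1(C)O` keeps the shared core and differs from compound 3 in the aromatic group on the carbonyl carbon (2-fluoro-4-(trifluoromethyl)phenyl in place of 3-(trifluoromethyl)phenyl on a carbonyl carbon).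

All three measured steps bear on this change, since each alters that same aromatic group. Trifluoromethyl in place of fluoro gave a 1.4-fold lower number from compound 1 to compound 2 (0.16 log units; within the scatter) and the two positions of the trifluoromethyl group gave a 1.6-fold higher number from compound 2 to compound 3 (0.21 log units; within the scatter), while the remaining comparison is a 1.1-fold higher number from compound 1 to compound 3 (0.05 log units; within the scatter). None of these left the scatter. For the measured compounds named here, no measured compound carries the 2-fluoro-4-(trifluoromethyl)phenyl group, so the expectation rests on these small steps alone.

In this assay no step beyond the scatter is therefore expected (estimated as a 1.4-fold lower number from compound 3 to compound 4 (0.13 log units; within the scatter)). The estimate for compound 4 is 28000 nM (expected range 15000 nM to 50000 nM).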

Compound 4, half-maximal inhibitory concentration: > 50000 nM
Compound 4: no number, only a limit; the forecaster's own chance of this, stated with the estimate: 8%; middle value at least 1.7-fold (0.25 log units) away from the limit.
By their numbers in this assay, from the lowest: compounds 2, 1 and 3 (each within the scatter of the next). At a limit, above all of these: compound 4.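

In this assay compound 4 gives > 50000 nM, which is a limit of the assay and not a number. Fluoro in place of hydrogen on an aromatic carbon gives an at least 2.1-fold higher number from compound 2 to compound 4 (0.32 log units; beyond the scatter), the only step in the series that is printed as beyond the scatter, whereas every earlier exchange within the aromatic group on the carbonyl carbon stayed within it, so this group is no longer shown to tolerate every change made to it. The two other floors, an at least 1.3-fold higher number from compound 3 to compound 4 (0.12 log units; that floor lies within the scatter) and an at least 1.4-fold higher number from compound 1 to compound 4 (0.17 log units; that floor lies within the scatter), lie within the scatter, so on those comparisons the 2-fluoro-4-(trifluoromethyl)phenyl group cannot be separated from the groups it replaces, and the loss can be read only against the 4-(trifluoromethyl)phenyl group.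

As far as these compounds go, the true size of all three steps remains open, as each is only a floor set by the limit. Also open is whether an amine or a carboxylic acid in place of the trifluoromethyl group would move the number in this assay in either direction, since all the groups shown carry only fluorine on the aromatic ring.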